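A Longer Acyl Chain on the Amide of Compound 1

The source may report more compounds than this note shows. Statements on the series, on what has been measured and on what is new or still open speak of the compounds shown alone.

Of the compounds shown here, two have been measured here: compound 1 `CC(=O)N[C@@H]1CCCc2c1cncc2N1CCc2cc(Cl)ccc2C1=O` and compound 2 `CCC1c2cc(Cl)ccc2C(=O)N1c1cccnc1`. In an ADME assay on cells for inhibition of cytochrome P450 11B1, mitochondrial (Homo sapiens), read by HTRF (a lower number here means a stronger inhibitor, a higher number a weaker inhibitor), compound 1 gives 3920 nM, and in the same test compound 2 gives 3340 nM. Compound 1 stands beside compound 2 with a gap that lies within the usual scatter, so the two cannot be told apart. Compound 3 `CCC(=O)N[C@@H]1CCCc2c1cncc2N1CCc2cc(Cl)ccc2C1=O` is the next one to be tested in this assay. It differs from compound 1 by methyl in place of hydrogen on a saturated chain carbon bound to a carbonyl carbon; the acetyl group becomes a propanoyl group, the acetamido an propanoylamino. For the measured compounds named here, no step between measured compounds speaks to this change, so only a small step is expected, a 1.0-fold lower number from compound 1 to compound 3 (0.00 log units; within the scatter), with no direction that would rise above the scatter. Compound 3 is therefore expected to give about 3900 nM, with a likely range from 1900 nM to 8000 nM.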

Compound 3, half-maximal inhibitory concentration: 3330 nM
Beside the measured number, compound 3's estimate is 1.2-fold (0.07 log units) above it; the range from low to high includes it.
By their numbers in this assay, from the lowest: compounds 3, 2 and 1 (each within the scatter of the next).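

Extending the acetyl group to a propanoyl group gives the first reading of a change at this place, a saturated chain carbon bound to a carbonyl carbon. In this assay the step is a 1.2-fold lower number from compound 1 to compound 3 (0.07 log units; within the scatter), so compound 1 and compound 3 cannot be told apart, and one added methyl here has no effect that this test can detect. No measurement shown offers a reason for this result.

On these data alone, a single small step says little about larger groups, so it stays open whether a longer chain such as butanoyl, a cyclopropyl ring or an amine at this place would move the number beyond the scatter. As far as these compounds go, it also stays open whether removing the acetyl group altogether, leaving a free amine on the core of compound 1, would matter more.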